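A Larger Group on the Oxygen of Compound 3

The source may report more compounds than this note shows. Statements on the series, on what has been measured and on what is new or still open speak of the compounds shown alone.

Three compounds share a core and differ only in the group on one oxygen. In a functional assay on HCT-116 cells (Homo sapiens) for antiproliferative activity, read by MTT assay, with a stated time of 48 h (on this read-out higher numbers stand for weaker inhibition and lower numbers for stronger inhibition), compound 1 `CCOc1cc(-c2ccc3c(ccn3C)c2)cn2c(-c3cc(OC)c(OC)c(OC)c3)nnc12`, carrying ethyl, gives 228 nM. Compound 2 `COc1cc(-c2nnc3c(OC4CCC4)cc(-c4ccc5c(ccn5C)c4)cn23)cc(OC)c1OC`, carrying cyclobutyl, gives 750 nM, and compound 3 `COc1cc(-c2nnc3c(OC4CC4)cc(-c4ccc5c(ccn5C)c4)cn23)cc(OC)c1OC`, carrying cyclopropyl, gives 135 nM.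

Compound 3 cannot be separated from compound 1, since a 1.7-fold lower number from compound 1 to compound 3 (0.23 log units; within the scatter) stays within the scatter. It stands clearly lower than compound 2, as a 5.6-fold lower number from compound 2 to compound 3 (0.74 log units; beyond the scatter) shows.

Compound 4 `CCCN1CC(Oc2cc(-c3ccc4c(ccn4C)c3)cn3c(-c4cc(OC)c(OC)c(OC)c4)nnc23)C1` has 1-propylazetidin-3-yl in place of cyclopropyl on an oxygen on an aromatic ring. The nearest guide is compound 2, whose cyclobutyl also brings a four-membered ring, with a 3.3-fold higher number from compound 1 to compound 2 (0.52 log units; beyond the scatter) marking a modest rise. Within the data shown here, no measured compound carries the nitrogen or the propyl chain, so this guide is only partial.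

A modest rise toward weaker inhibition is therefore expected, with a 3.0-fold higher number from compound 3 to compound 4 (0.47 log units; beyond the scatter) as the estimated step. Compound 4 is estimated at 400 nM, with an expected range of 90 nM to 1800 nM.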

Compound 4, half-maximal inhibitory concentration: 675 nM
Beside the measured number, compound 4's estimate is 1.7-fold (0.23 log units) below it, and the stated range covers the measured number.
By their numbers in this assay, from the lowest: compounds 3 and 1 (each within the scatter of the next); then compounds 4 and 2 (each within the scatter of the next).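

Among these compounds, compound 4 shows that this oxygen can carry 1-propylazetidin-3-yl, the first group here with a ring nitrogen and a propyl chain, and antiproliferative activity remains in this assay. That larger group still has a cost against the two smaller groups, with a 5.0-fold higher number from compound 3 to compound 4 (0.70 log units; beyond the scatter) and a 3.0-fold higher number from compound 1 to compound 4 (0.47 log units; beyond the scatter), while a 1.1-fold lower number from compound 2 to compound 4 (0.05 log units; within the scatter) means that it cannot be told apart from cyclobutyl, the all-carbon group with a four-membered ring. Nothing measured here bears on the reason for these steps.

Going by these compounds, how much the ring nitrogen and the propyl chain each count on their own remains open, and a 1-methylazetidin-3-yl group on this oxygen would begin to separate them. On these data alone, how an open-chain amine or a carboxylic acid at this position would compare also remains open.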